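The source may hold more compounds than are shown below. What is called first, only, known or untested is meant among the compounds shown, and "the series" means these compounds.

In an ADME assay (liver) for metabolic stability, with Liver microsome (Homo sapiens) as the target, using microsomes and NADPH, with a stated time of 30 min, tested at 1 uM (on this read-out lower numbers stand for slow clearance and higher numbers for fast clearance), compound 3 `Nc1ccc(S(=O)(=O)N2CCN(c3ncc(C(O)(C(F)(F)F)C(F)(F)F)cc3-c3ccncc3)CC2)cn1` gives 15 mL.min-1.g-1. Compound 1 `CCn1cc(-c2cc(C(O)(C(F)(F)F)C(F)(F)F)cnc2N2CCN(S(=O)(=O)c3ccc(N)nc3)CC2)cn1` gives 20 mL.min-1.g-1, within the scatter of compound 3, while compound 2 `CC(C)n1cc(-c2cc(C(O)(C(F)(F)F)C(F)(F)F)cnc2N2CCN(S(=O)(=O)c3ccc(N)nc3)CC2)cn1` gives 38 mL.min-1.g-1. Compound 4 `COc1ccc(-c2cc(C(O)(C(F)(F)F)C(F)(F)F)cnc2N2CCN(S(=O)(=O)c3ccc(N)nc3)CC2)cn1` differs from compound 3 as follows: 6-methoxypyridin-3-yl in place of pyridin-4-yl on an aromatic carbon. In short, 6-methoxypyridin-3-yl stands in place of pyridin-4-yl on an aromatic carbon. Two measured replacements at this place bear on it: a 1.3-fold lower number from compound 1 to compound 3 (0.12 log units; within the scatter) and a 2.5-fold lower number from compound 2 to compound 3 (0.40 log units; beyond the scatter). Both arrive at pyridin-4-yl with a lower number, so leaving it is expected to give a modest rise at most. Among the compounds with values here, no measured compound carries 6-methoxypyridin-3-yl, which keeps this expectation loose. The expected change is a 1.7-fold higher number from compound 3 to compound 4 (0.22 log units; within the scatter). Compound 4 is estimated at 25 mL.min-1.g-1, with an expected range of 12 mL.min-1.g-1 to 50 mL.min-1.g-1.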

Compound 4, intrinsic clearance in microsomes: 25 mL.min-1.g-1
Compound 4: middle estimate and measured number agree at the digits printed, and the stated range covers the measured number.
By their numbers in this assay, from the lowest: compounds 3, 1, 4 and 2 (each within the scatter of the next, the first and the last beyond it).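

In this assay, 6-methoxypyridin-3-yl cannot be told apart from any of the three other groups on this aromatic carbon (a 1.7-fold higher number from compound 3 to compound 4 (0.22 log units; within the scatter); a 1.3-fold higher number from compound 1 to compound 4 (0.10 log units; within the scatter); a 1.5-fold lower number from compound 2 to compound 4 (0.18 log units; within the scatter)). Compound 4 thus sits within the scatter of compound 2 and of compound 3, although those two are separated from each other. Nothing measured here gives a reason for these numbers.

Going by these compounds, whether an amine or a carboxylic acid on this aromatic carbon would move the clearance number beyond the scatter remains open. Also open, on these data alone, is how a pyridin-3-yl group without the methoxy would read.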